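Swapping methoxy for tert-butyl in compound 4

This account rests on a few compounds, and the source may have more. Where it says the series, first, only, none or still open, it means among the compounds named here.

In an ADME assay on HEK293 cells (Homo sapiens) for cytotoxicity, with a stated time of 72 h (a lower number here means that less compound is needed, a higher number that more compound is needed for the effect), compound 3 (`COc1cccc(NC(=O)Nc2cc(C)nc3ccccc23)c1`) gives only a limit, > 25000 nM. Compound 1 (`Cc1cc(NC(=O)Nc2cccc([N+](=O)[O-])c2)c2ccccc2n1`) also gives only a limit, > 25000 nM. Compound 2 (`COC(=O)c1cccc(NC(=O)Nc2cc(C)nc3ccccc23)c1`) gives a true number, 26000 nM. Compound 4 (`Cc1cc(NC(=O)Nc2cccc(C(C)(C)C)c2)c2ccccc2n1`) carries tert-butyl in place of methoxy on an aromatic carbon, meta to a large group: tert-butyl in place of methoxy on an aromatic carbon. Two measured steps also change the group on that carbon: a step that the two limits leave unreadable from compound 1 to compound 3 and a step that the limit leaves unreadable from compound 2 to compound 3. Neither has a size that can be read, so they offer no sign of a real shift in either direction. The expected result is a number no higher from compound 3 to compound 4 (the limit leaves the size open), with no step beyond the scatter anticipated. For compound 4 the estimate is 25000 nM, with an expected range of 10000 nM to 50000 nM.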

Compound 4, half-maximal effective concentration: > 25000 nM
Compound 4 gave a limit, no number (the forecaster's own chance of this, stated with the estimate: 65%); the middle value sits exactly at the limit.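

The steps to compound 4 from compound 1, compound 2 and compound 3 cannot be read, since compound 4 also stops at a limit: the limit of > 25000 nM in this assay, at which 3 of the 4 values shown sit. From the compounds shown here alone, whether tert-butyl, methoxy or nitro on that aromatic carbon changes the true number stays open.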